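Replacing a bromophenyl by a thiophene: the expected cost

The source may hold more compounds than are shown below. What is called first, only, known or untested is meant among the compounds shown, and "the series" means these compounds.

Compound 1, `Cc1ccsc1/C=C(/SCc1ccc(Cl)cc1)C(=O)c1ccc(Cl)cc1`: 50000 nM
Compound 2, `O=C(/C(=C\c1ccc(Br)cc1)SCc1ccc(Cl)cc1)c1ccc(Cl)cc1`: 1000 nM
Compound 3, `Cc1ccc(CS/C(=C/c2ccc(Br)cc2)C(=O)c2ccc(Cl)cc2)cc1`: 10000 nM

The three measured compounds were tested in a functional assay on DU-145 cells (Homo sapiens) for inhibition, read by trypan blue exclusion, with a stated time of 96 h; a higher number here means a weaker inhibitor of growth, a lower number a stronger inhibitor of growth. Compound 2 stands out, as its steps to both others are beyond the scatter. From compound 2 to compound 1 the change is 3-methylthiophen-2-yl in place of 4-bromophenyl on a double-bonded chain carbon bound to a double-bonded chain carbon, and this change made a large step: a 50-fold higher number from compound 2 to compound 1 (1.70 log units; beyond the scatter). From compound 2 to compound 3 the change is methyl in place of chloro on an aromatic carbon, a smaller but still clear step: a 10-fold higher number from compound 2 to compound 3 (1.00 log units; beyond the scatter).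

Compound 4, `Cc1ccc(CS/C(=C/c2sccc2C)C(=O)c2ccc(Cl)cc2)cc1`, has not yet been measured in this assay. It differs from compound 3 by 3-methylthiophen-2-yl in place of 4-bromophenyl on a double-bonded chain carbon bound to a double-bonded chain carbon. Going by the values given here, this is the same change as the one from compound 2 to compound 1, made on a different core: the two cores differ by methyl in place of chloro on an aromatic carbon, and the place of the change is described in the same words in both cases.

Among the compounds with values here, on that basis compound 4 is expected to lie well above compound 3 in this assay, with an expected step of a 20-fold higher number from compound 3 to compound 4 (1.30 log units; beyond the scatter), resting on the single earlier example of the same change, a 50-fold higher number from compound 2 to compound 1 (1.70 log units; beyond the scatter). Within the data shown here, the expectation is held loosely, since only one prior step supports it and compound 1 already gives a high number, so the measurement may come back as a limit. The estimate for compound 4 in this assay is 200000 nM, with a range from 40000 nM to 1000000 nM.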

Compound 4, concentration for 50% growth inhibition: 10000 nM
Beside the measured number, compound 4's estimate is 20-fold (1.30 log units) above it; the whole stated range lies above it.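

In this assay, placing 3-methylthiophen-2-yl where 4-bromophenyl stood on the core of compound 3 gave no change at the digits printed from compound 3 to compound 4 (within the scatter), so the large cost seen on the core of compound 2 did not carry over to this core, and the two steps differ: the same change on two cores in this assay, a 50-fold higher number (1.70 log units; beyond the scatter) from compound 2 to compound 1 and no change at the digits printed (within the scatter) from compound 3 to compound 4, 50-fold (1.70 log units) apart, beyond the scatter of two such steps. The other change in this set of compounds shows the same dependence, since methyl in place of chloro on an aromatic carbon gave a 5.0-fold lower number from compound 1 to compound 4 (0.70 log units; beyond the scatter) with 3-methylthiophen-2-yl present, opposite in direction to the step seen with 4-bromophenyl present: the same change on two cores in this assay, a 10-fold higher number (1.00 log units; beyond the scatter) from compound 2 to compound 3 and a 5.0-fold lower number (0.70 log units; beyond the scatter) from compound 1 to compound 4, 50-fold (1.70 log units) apart, beyond the scatter of two such steps. Across these compounds the effect of either change therefore depends on the other, so the step from one core cannot be carried to the other, but the data do not show why, and with only one pair on each core they give no general rule for the series.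

The compounds shown leave open whether a methoxy group or an amine on that aromatic carbon would follow the chloro core or the methyl core. They also leave open how an unsubstituted thiophene or a pyridine would behave on the double-bonded chain carbon on either core.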